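Swapping Acetyl for Amino: Expected Effect on Cytotoxicity

The source may hold more compounds than are shown below. What is called first, only, known or untested is meant among the compounds shown, and "the series" means these compounds.

Among the compounds with values here, in an ADME assay on BJ cells (Homo sapiens) for cytotoxicity, with a stated time of 72 h (on this read-out higher numbers stand for an effect only at larger amounts of compound and lower numbers for an effect already at smaller amounts), compound 1 `CC(=O)c1ccc(NC(=O)Nc2cc(C)nc3ccccc23)cc1` gives 22000 nM, the only plain number among the three measured compounds. Compound 2 `Cc1cc(NC(=O)Nc2ccc3[nH]cnc3c2)c2ccccc2n1` reaches only a limit of the assay in this assay, namely > 25000 nM. Compound 3 `Cc1cc(NC(=O)Nc2cc(Cl)cc(Cl)c2)c2ccccc2n1` likewise gives only a limit in this assay, > 25000 nM. Within the data shown here, compound 1 therefore stands apart as the single compound with a number rather than a limit, given (the limit of > 25000 nM in this assay, at which 2 of the 3 values shown sit). Among the measured compounds shown here, no step between two measured compounds that differ in one place is available, so no measured step sets a scale.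

Compound 4 `Cc1cc(NC(=O)Nc2ccc(N)cc2)c2ccccc2n1` is not yet measured. It differs from compound 1 in one place: amino in place of acetyl on an aromatic carbon. Because compound 1 gives 22000 nM, a shift beyond the scatter in either direction is not expected for compound 4. Compound 4 is estimated to give 25000 nM in this assay, between 10000 nM and 60000 nM. The step of a 1.1-fold higher number from compound 1 to compound 4 (0.06 log units; within the scatter) that this estimate means is expected to stay within the scatter.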

Compound 4, half-maximal effective concentration: > 25000 nM
Compound 4: no number, only a limit; the forecaster's own chance of this, stated with the estimate: 55%; the middle value lies on the limit itself.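

In this assay compound 4 gives > 25000 nM, which is a limit of the assay and not a number. The earlier compounds shown here offered no comparison differing in one place, whereas amino in place of acetyl, on an aromatic carbon para to a large group, now gives an at least 1.1-fold higher number from compound 1 to compound 4 (0.05 log units; that floor lies within the scatter), so nothing here points to a lower number with amino at this position. The true size of this step cannot be read, because the read-out stops at the same ceiling for most of the series: the limit of > 25000 nM in this assay, at which 3 of the 4 values shown sit.

Only acetyl and amino are shown at this position. Within the data shown here, it remains open whether a carboxylic acid or a longer alkyl chain there would give a number clearly lower than the one compound 1 gives, 22000 nM.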